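Trichloromethyl for Nitro: a Repeated Change, Measured Once

The source may report more compounds than this note shows. Statements on the series, on what has been measured and on what is new or still open speak of the compounds shown alone.

Measured compounds:
compound 1, `O=[N+]([O-])c1ccc(Sc2ccc(NC(=S)Oc3ccc(O)cc3)cc2)cc1`, 5.25
compound 2, `Oc1ccc(OC(=S)Nc2ccc(Sc3ccc(C(Cl)(Cl)Cl)cc3)cc2)cc1`, 7.43
compound 3, `CC(=O)Nc1ccc(OC(=S)Nc2ccc(Sc3ccc([N+](=O)[O-])cc3)cc2)cc1`, 5.06

Of the compounds shown here, three have been measured in a physicochemical assay for lipophilicity (on this read-out higher numbers stand for higher lipophilicity and lower numbers for lower lipophilicity), and a fourth, compound 4 with the structure `CC(=O)Nc1ccc(OC(=S)Nc2ccc(Sc3ccc(C(Cl)(Cl)Cl)cc3)cc2)cc1`, has not.

Compound 1 and compound 2 share a core and differ in one group: trichloromethyl in place of nitro on an aromatic carbon. This change carries a number 2.18 log units higher from compound 1 to compound 2 (beyond the scatter). Compound 1 and compound 3 differ in another place: acetamido in place of hydroxy on an aromatic carbon. That change gives a number 0.19 log units lower from compound 1 to compound 3 (within the scatter), so on this read-out compound 1 and compound 3 cannot be told apart.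

Compound 4 relates to compound 3 exactly as compound 2 relates to compound 1: trichloromethyl in place of nitro on an aromatic carbon. The surroundings of the change are described in the same words in both pairs, so this is the same change made on a core that differs only in the way just described. Because the step of a number 2.18 log units higher from compound 1 to compound 2 (beyond the scatter) was large and the core change a number 0.19 log units lower from compound 1 to compound 3 (within the scatter) was small, the step from compound 3 to compound 4 is expected to be about as large, namely a number 2.18 log units higher from compound 3 to compound 4 (beyond the scatter). Within the data shown here, only one earlier example of this change is known here, so the expectation rests on a single pair.

For compound 4 in this assay the estimate is 7.24, expected to lie between 6.8 and 7.7.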

Compound 4, partition coefficient: 6.71
Compound 4: the middle estimate sits 0.53 log units above what was measured; the measured number lies below the stated range.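

In this assay, trichloromethyl in place of nitro on the core carrying acetamido gave a clear rise (a number 1.65 log units higher from compound 3 to compound 4 (beyond the scatter)), so the change kept its direction and stayed large on a second core, though the step was smaller than on the core carrying hydroxy (a number 2.18 log units higher from compound 1 to compound 2 (beyond the scatter)). The two changes also do not simply add up in these four compounds: acetamido in place of hydroxy could not be told from no change on the nitro compounds (a number 0.19 log units lower from compound 1 to compound 3 (within the scatter)), yet on the trichloromethyl compounds it gave a step beyond the scatter (a number 0.72 log units lower from compound 2 to compound 4 (beyond the scatter)). Two pairs show that the direction of the change held here, but they do not show how much of a step to expect on any further core, and nothing available explains why the size of the step differed between these two cores.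

The compounds shown leave open how the step from nitro to trichloromethyl would run on a core carrying an amine or a carboxylic acid where hydroxy and acetamido stand. They also leave open whether a nitrile in place of nitro would follow the same course on both cores.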